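The compounds below may be only part of what the source reports. "The series", "measured", "known", "first", "only" and "open" are said of these compounds alone.

In a functional assay on the whole organism with Canis familiaris (Canis lupus familiaris) as the target (a higher number here means that more compound is needed for the effect, a lower number that less compound is needed), compound 1 `COc1ccc(-c2nc3cc[nH]cc-3n2)cc1` gives 1.7 mg/kg and compound 2 `Clc1ccc(-c2nc3cc[nH]cc-3n2)c(Cl)c1` gives 0.7 mg/kg while compound 3 `COc1ccc(-c2nc3cc[nH]cc-3n2)c(OC)c1` gives 0.3 mg/kg as the lowest of the three numbers. Compound 4 `COc1cc(Cl)ccc1-c1nc2cc[nH]cc-2n1` has chloro in place of methoxy on an aromatic carbon of compound 3 (chloro in place of methoxy on an aromatic carbon). Among the measured compounds shown here, no measured step shows this swap. For the measured compounds named here, the only measured step (a 5.7-fold lower number from compound 1 to compound 3 (0.75 log units; beyond the scatter)) adds a methoxy and is modest, so it bears only loosely. Compound 2 carries chloro wherever compound 3 carries methoxy, and compound 2 reads higher (0.7 mg/kg). Swapping just one of those groups should therefore give a small rise in this assay that may stay within the scatter. The expected step runs a 1.5-fold higher number from compound 3 to compound 4 (0.18 log units; within the scatter) in this estimate. For compound 4 the estimated value is 0.45 mg/kg with an expected range (0.2 mg/kg to 1 mg/kg).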

Compound 4, dose for half-maximal effect: 0.23 mg/kg
The estimate for compound 4 lay 2.0-fold (0.29 log units) above the measured number; the range from low to high includes it.
By their numbers in this assay, from the lowest: compounds 4 and 3 (each within the scatter of the next); then compound 2; then compound 1.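

In this assay, chloro in place of methoxy on the carbon para to a group of 9 heavy atoms gives a change within the scatter (a 1.3-fold lower number from compound 3 to compound 4 (0.12 log units; within the scatter)), so the two groups cannot be told apart at this position. At the other substituted carbon, methoxy in place of chloro gives a change beyond the scatter (a 3.0-fold lower number from compound 2 to compound 4 (0.48 log units; beyond the scatter)). Nothing available explains either step.

The compounds shown leave open whether an amine or a carboxylic acid at the position para to a group of 9 heavy atoms would keep the number as low.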